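The source may report more compounds than this note shows. Statements on the series, on what has been measured and on what is new or still open speak of the compounds shown alone.

Three compounds share one core and differ only in the aromatic group carried on an amide-type nitrogen. Compound 1 `Cc1nc2cc(NC(=O)N3CCN(Cc4cccc(Oc5ccc(Cl)cc5)c4)CC3)ccc2o1` gives 7.7 nM in an assay on isolated protein for inhibition of Fatty-acid amide hydrolase 1 (Homo sapiens), with a stated time of 60 min; on this read-out lower numbers stand for stronger inhibition and higher numbers for weaker inhibition. Compound 2 `O=C(Nc1cncc2ccccc12)N1CCN(Cc2cccc(Oc3ccc(Cl)cc3)c2)CC1` gives 6.7 nM, and compound 3 `O=C(Nc1noc2ccccc12)N1CCN(Cc2cccc(Oc3ccc(Cl)cc3)c2)CC1` gives 10 nM. Compound 2 shows the lowest number of the three, yet the step of a 1.1-fold lower number from compound 1 to compound 2 (0.06 log units; within the scatter) and the step of a 1.3-fold higher number from compound 1 to compound 3 (0.11 log units; within the scatter) both stay within the scatter, so no order among them is established. Compound 4 `O=C(Nc1noc2ccncc12)N1CCN(Cc2cccc(Oc3ccc(Cl)cc3)c2)CC1` is not yet measured; its change from compound 2 is a group of 9 heavy atoms (6 carbon, 2 nitrogen, 1 oxygen; one five-membered aromatic ring with 2 hetero atoms, one six-membered aromatic ring with 1 hetero atom) in place of a group of 10 heavy atoms (9 carbon, 1 nitrogen; one six-membered aromatic ring of carbon only, one six-membered aromatic ring with 1 hetero atom), on an amide-type nitrogen. The nearest guide is the step of a 1.5-fold higher number from compound 2 to compound 3 (0.17 log units; within the scatter), which also removes isoquinolin-4-yl for a group holding one five-membered aromatic ring with 2 hetero atoms, and it stayed within the scatter. Compound 4 is therefore expected to show no step beyond the scatter, estimated at 10 nM with a range from 4 nM to 25 nM. That estimate means an expected step of a 1.5-fold higher number from compound 2 to compound 4 (0.17 log units; within the scatter).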

Compound 4, half-maximal inhibitory concentration: 180 nM
Beside the measured number, compound 4's estimate is 18-fold (1.26 log units) below it, and the stated range ends below it.
By their numbers in this assay, from the lowest: compounds 2, 1 and 3 (each within the scatter of the next); then compound 4.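

Swapping only the carbon-only six-membered ring of compound 3 for a six-membered aromatic ring with 1 hetero atom gives an 18-fold higher number from compound 3 to compound 4 (1.26 log units; beyond the scatter) at this amide-type nitrogen, so this position is less forgiving than the earlier compounds suggested, and a 27-fold higher number from compound 2 to compound 4 (1.43 log units; beyond the scatter) and a 23-fold higher number from compound 1 to compound 4 (1.37 log units; beyond the scatter) agree with that. Such a ring alone does not account for the result, since compound 2 also carries one and stays within the scatter of compound 1 and compound 3. No supporting measurement explains this rise. Still open, as far as these compounds go, is whether a methyl group or an amine on the ring system of compound 4 would bring the number back down.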